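The source may hold more compounds than are shown below. What is called first, only, known or untested is meant among the compounds shown, and "the series" means these compounds.

In an assay on isolated protein for inhibition of sphingomyelin phosphodiesterase (Homo sapiens), read by fluorescence, with a stated time of 30 min (on this read-out higher numbers stand for weaker inhibition and lower numbers for stronger inhibition), compound 1 `O=C(NO)c1cccc(OCc2ccc(-c3ccccc3)cc2)c1` gives 19600 nM. Compound 2 `O=C(NO)c1cccc(OCc2ccc(-c3noc(-c4ccccc4)n3)cc2)c1` adds a five-membered aromatic ring with 2 nitrogen and 1 oxygen that bears a phenyl. On these data alone, for compound 2 the assay reports only a limit, > 100000 nM, so compound 2 stands at the limit of > 100000 nM in this assay, at which 1 of the 2 values shown sits, and its true value remains unknown. Compound 3 `O=C(NO)c1cccc(OCc2ccc(-c3noc(Cc4ccccc4)n3)cc2)c1` differs from compound 2 by benzyl in place of phenyl on an aromatic carbon. Within the data shown here, no step between measured compounds exists here, and compound 2 is known only as a limit, so there is no measured step to lean on. Compound 3 is expected to stay weak, with a step of a number no higher from compound 2 to compound 3 (the limit leaves the size open) that is expected to be small or none beyond the scatter. The estimate for compound 3 is 100000 nM, within a range from 30000 nM to 300000 nM. Whether compound 3 yields a number or again only a limit remains the open question.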

Compound 3, half-maximal inhibitory concentration: 7830 nM
Compound 3: the middle estimate sits 13-fold (1.11 log units) above what was measured; the whole stated range lies above it.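

In this assay, the aromatic carbon of the five-membered ring, next to the ring oxygen, proves sensitive to the group it carries: benzyl in place of phenyl gives an at least 12-fold lower number from compound 2 to compound 3 (1.10 log units; beyond the scatter). Among these compounds, the two groups count the same six-membered aromatic ring and no hydrogen-bond donors or acceptors, yet the step lies beyond the scatter, and it is the first measured step at this position. The reading for compound 2 is a limit and not a number, so the true size of the step stays unknown: the limit of > 100000 nM in this assay, at which 1 of the 3 values shown sits.

The compounds shown leave open whether this gain is particular to benzyl or would carry over to a longer chain such as phenethyl. They also leave open how an amine or a carboxylic acid on the benzyl ring would read.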